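Trading a Halogenated Aryl for a Methylphenyl

The source may hold more compounds than are shown below. What is called first, only, known or untested is meant among the compounds shown, and "the series" means these compounds.

Of the compounds shown here, three sharing one core have been measured in a functional assay on MCF7 cells (Homo sapiens) for cytotoxicity, read by MTT assay, with a stated time of 72 h; a higher number here means a weaker inhibitor, a lower number a stronger inhibitor. Compound 3 `Cc1cc(=O)n(-c2ccc(Br)cc2F)nc1C(=O)Nc1ccc(Oc2ncnc3sccc23)cc1` gives 15200 nM, the highest of the three numbers. Compound 1 `Cc1cc(=O)n(-c2ccc(Br)cc2F)nc1C(=O)Nc1ccc(Oc2ncnc3ccsc23)cc1` differs from it only in the bicyclic group on the ether oxygen and gives 9360 nM; the step of a 1.6-fold higher number from compound 1 to compound 3 (0.21 log units; within the scatter) shows that this swap did not move the number beyond the scatter. Among the compounds with values here, compound 2 `Cc1cc(=O)n(-c2ccc(F)c(F)c2)nc1C(=O)Nc1ccc(Oc2ncnc3ccsc23)c(F)c1`, which carries a different aryl group on the ring nitrogen and an additional fluorine on the central ring, gives 6900 nM, and this is the only value that sits beyond the scatter from compound 3.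

Compound 4 `Cc1ccc(-n2nc(C(=O)Nc3ccc(Oc4ncnc5sccc45)cc3)c(C)cc2=O)cc1` differs from compound 3 in one place: 4-methylphenyl in place of 4-bromo-2-fluorophenyl on an aromatic nitrogen. Within the data shown here, no measured pair isolates this change. Compound 2 does vary the aryl on the ring nitrogen, but it also changes the central ring, so it cannot be read as a clean comparison. Among the measured compounds shown here, the one clean step that is known, from compound 1 to compound 3, concerns a different part of the molecule and stayed within the scatter. With nothing pointing in either direction, the expectation for compound 4 is a step of no more than the scatter, a 1.2-fold lower number from compound 3 to compound 4 (0.07 log units; within the scatter). The estimated value for compound 4 is 13000 nM, with a range from 5000 nM to 35000 nM.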

Compound 4, half-maximal inhibitory concentration: > 40000 nM
Compound 4: a limit, no number; the forecaster's own chance of this, stated with the estimate: 10%; at least 3.0-fold (0.48 log units) between middle value and limit.
By their numbers in this assay, from the lowest: compounds 2, 1 and 3 (each within the scatter of the next, the first and the last beyond it). At a limit, above all of these: compound 4.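

Within the data shown here, this is the first clean reading of the group on the aromatic nitrogen, and it shows that the position is not indifferent to the change: in this assay, the swap from 4-bromo-2-fluorophenyl to 4-methylphenyl gives an at least 2.6-fold higher number from compound 3 to compound 4 (0.42 log units; beyond the scatter). The step at the ether oxygen, a 1.6-fold higher number from compound 1 to compound 3 (0.21 log units; within the scatter), stayed within the scatter, so of the two places changed singly among these compounds, only the group on the aromatic nitrogen moved the number beyond it. Compound 4 gives a limit of the assay and not a number, so the full size of this step stays unknown: the limit of > 40000 nM in this assay, at which 1 of the 4 values shown sits.

The change removes the bromine and the fluorine and brings in the methyl group all at once, so the compounds shown cannot say which of these carries the step, and a plain unsubstituted phenyl or a pyridine ring on the same nitrogen would begin to separate them. From the compounds shown here alone, it also remains open whether the same swap would give a similar step on the core of compound 1, where the bicyclic group on the ether oxygen differs.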